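Aryl sulfonyl at the ring nitrogen of compound 3

This account rests on a few compounds, and the source may have more. Where it says the series, first, only, none or still open, it means among the compounds named here.

Measured in an assay on cells for inhibition of Pendrin (Mus musculus), read by fluorescence, with a stated time of 10 min; a higher number here means a weaker inhibitor, a lower number a stronger inhibitor:
- compound 1, `Cn1nc(COc2cc(F)cc(F)c2)c2c1CCN(C(=O)Nc1ccc(Br)cc1)C2`: 3300 nM
- compound 2, `Cn1nc(COc2cc(F)cc(F)c2)c2c1CCN(C(=O)NC1CCCCC1)C2`: a limit of this assay, > 10000 nM
- compound 3, `Cn1nc(COc2cc(F)cc(F)c2)c2c1CCN(S(C)(=O)=O)C2`: a limit of this assay, > 10000 nM

Compound 3 sits at the limit of > 10000 nM in this assay, at which 2 of the 3 values shown sit. It gives no number, so its place against compound 1 is known only as a bound: an at least 3.0-fold higher number from compound 1 to compound 3 (0.48 log units; beyond the scatter). The same holds for compound 2, and the pair of limits leaves the step that the two limits leave unreadable from compound 2 to compound 3 without a readable size.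

Compound 4 is `Cn1nc(COc2cc(F)cc(F)c2)c2c1CCN(S(=O)(=O)c1ccc(Cl)cc1)C2`. Against compound 3 the change is 4-chlorophenyl in place of methyl on a sulfonyl sulfur. For the measured compounds named here, no measured step swaps a group on the sulfonyl sulfur; the nearest comparison is on the urea side, where a 4-bromophenyl against cyclohexyl gave an at least 3.0-fold higher number from compound 1 to compound 2 (0.48 log units; beyond the scatter), so an aromatic ring in place of an aliphatic group went with the lower number there. Only compound 1 carries such a ring among the measured three, so this rests on a single pair.

For compound 4 a lower number than the limit of compound 3 is expected, roughly in the region of compound 1, with the step estimated as an at least 2.0-fold lower number from compound 3 to compound 4 (0.30 log units; that floor lies within the scatter). The estimate for compound 4 in this assay is 5000 nM, within 1500 nM to 20000 nM, with a fair chance that only a limit is returned.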

Compound 4, half-maximal inhibitory concentration: > 10000 nM
Compound 4: only a limit was reported; the forecaster's own chance of this, stated with the estimate: 40%; middle value at least 2.0-fold (0.30 log units) from the limit.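

In this assay compound 4 gives only a limit of the assay, > 10000 nM, so a 4-chlorophenyl on the sulfonyl sulfur does not by itself bring a readable value. For the compounds shown here, the link between an aromatic ring and the lower number, which rested on the urea pair alone, does not carry over to the sulfonyl side, and compound 4 goes against it, leaving compound 1 as the only compound with a number: the limit of > 10000 nM in this assay, at which 3 of the 4 values shown sit. Putting (4-chlorophenyl)sulfonyl in place of (4-bromophenyl)carbamoyl on the amine nitrogen in a ring gives an at least 3.0-fold higher number from compound 1 to compound 4 (0.48 log units; beyond the scatter), so an aromatic ring is not enough here without the carbamoyl link, while the steps from compound 2 and from compound 3 to compound 4 join two limits and cannot be read.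

Open, from the compounds shown here alone, is whether the gap between compound 1 and compound 4 follows the change of link or the change of halogen, which a (4-chlorophenyl)carbamoyl or a (4-bromophenyl)sulfonyl group at the same nitrogen would separate. Also open, going by these compounds, is whether any sulfonyl group can give a number here, for instance a benzylsulfonyl or a sulfonyl-bound phenyl carrying a carboxylic acid.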